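The source may report more compounds than this note shows. Statements on the series, on what has been measured and on what is new or still open speak of the compounds shown alone.

Working notes on the series. Compound 1 `C/N=C(\S)CCn1nc(-c2ccccc2)ccc1=O` and compound 2 `CC/N=C(\S)CCn1nc(-c2ccccc2)ccc1=O` share one core; compound 3 `N=C(S)CCn1ncccc1=O` and the not yet measured compound 4 `CC(CC(=N)S)n1ncccc1=O` share another. The difference between the two cores is not broken down here.

In a functional assay on the whole organism (stomach) with Rattus norvegicus as the target (on this read-out lower numbers stand for an effect already at smaller amounts and higher numbers for an effect only at larger amounts of compound), compound 1 gives 58.5 mg/kg and compound 2 gives 100 mg/kg. The change between them is methyl in place of hydrogen on a saturated chain carbon bound to a double-bonded nitrogen, and it brings a 1.7-fold higher number from compound 1 to compound 2 (0.23 log units; within the scatter). For compound 3 only a limit of this assay is recorded, > 100 mg/kg, not a number. That value sits at the limit of > 100 mg/kg in this assay, at which 1 of the 3 values shown sits.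

Compound 4 is set apart from compound 3 by methyl in place of hydrogen on a saturated chain carbon bound to an aromatic nitrogen and a saturated chain carbon. For the measured compounds named here, this is the same kind of change as the one from compound 1 to compound 2, but the place is not the same: there the saturated chain carbon is bound to a double-bonded nitrogen, here it is bound to an aromatic nitrogen and a saturated chain carbon. The matching change is seen only once among the measured compounds, and it stayed within the scatter.

Going by the values given here, compound 4 is therefore expected to give about 150 mg/kg, a step that the limit leaves unreadable from compound 3 to compound 4, since the one comparable step reads a 1.7-fold higher number from compound 1 to compound 2 (0.23 log units; within the scatter). With compound 3 itself at a limit, the estimate for compound 4 most likely comes back as a limit as well.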

Compound 4, dose for half-maximal effect: > 100 mg/kg
Compound 4 was reported as a limit (the forecaster's own chance of this, stated with the estimate: 70%); the middle value is on the limit's open side.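

No step can be read from compound 3 to compound 4, as both are recorded only as limits: the limit of > 100 mg/kg in this assay, at which 2 of the 4 values shown sit.

The compounds shown leave open what methyl in place of hydrogen on a saturated chain carbon bound to an aromatic nitrogen and a saturated chain carbon does in this assay.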